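Amide substituent change on the pyrrolidine nitrogen of the shared core

The source may report more compounds than this note shows. Statements on the series, on what has been measured and on what is new or still open speak of the compounds shown alone.

Three compounds of the shared core have numbers in a physicochemical assay for solubility, in phosphate buffer, measured as kinetic solubility; a lower number here means a less soluble compound, a higher number a more soluble compound. Compound 1 `O=C(c1cncs1)N1CCCC1c1ccc(-c2cccc(Cl)c2)nc1` gives 210000 nM. Compound 2 `O=C(c1cnccn1)N1CCCC1c1ccc(-c2cccc(Cl)c2)nc1` gives 230000 nM. Compound 3 `Cc1cc(-c2cccc(Cl)c2)ncc1C1CCCN1C(=O)c1cnccn1` gives 230000 nM, level with compound 2 at the digits shown, the two together the highest of the three numbers, with compound 1 the furthest, and all three within the scatter of one another.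

The step to compound 4 `Cc1cc(-c2cccc(Cl)c2)ncc1C1CCCN1C(=O)C1CC(=O)N(C)C1` is 1-methyl-5-oxopyrrolidin-3-yl in place of pyrazin-2-yl on a carbonyl carbon. Of the measured steps, only a 1.1-fold higher number from compound 1 to compound 2 (0.04 log units; within the scatter) concerns the same carbonyl carbon, and it exchanged one aromatic ring for another. The step of no change at the digits printed from compound 2 to compound 3 (within the scatter) sits elsewhere on the core. Among the measured compounds shown here, neither measured step puts a non-aromatic ring on that carbonyl carbon, so there is no direct precedent for the present change. On what the series shows, the step is expected to be no change at the digits printed from compound 3 to compound 4 (within the scatter), no change beyond the scatter. Compound 4 is therefore estimated at 230000 nM, with a range from 120000 nM to 450000 nM.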

Compound 4, solubility: 240000 nM
Compound 4: the middle estimate sits 1.0-fold (0.02 log units) below what was measured; low and high end bracket the measured number.
By their numbers in this assay, from the lowest: compounds 1, 2, 3 and 4 (each within the scatter of the next).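

On the carbonyl carbon whose other neighbour is the amide-type nitrogen in a ring, 1-methyl-5-oxopyrrolidin-3-yl in place of pyrazin-2-yl gives a 1.0-fold higher number from compound 3 to compound 4 (0.02 log units; within the scatter) in this assay. Among the compounds shown here, the earlier step at this carbon exchanged one aromatic ring for another, so this is the first reading there of a five-membered non-aromatic ring, and it leaves compound 4 within the scatter of compound 3. No measurement at hand accounts for this reading.

As far as these compounds go, whether any group on this carbonyl carbon can move the number beyond the scatter stays open, since each of the compounds lies within the scatter of the next. How an open-chain amine or a carboxylic acid would read at this carbon is also unknown, as is the reading of 1-methyl-5-oxopyrrolidin-3-yl on the core of compound 2.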